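This account rests on a few compounds, and the source may have more. Where it says the series, first, only, none or still open, it means among the compounds named here.

In an assay on membranes from HEK293 cells for displacement of a labelled ligand from adenosine receptor A2b (Homo sapiens), read by scintillation counting, with a stated time of 30 min, tested at 1 uM (on this read-out lower numbers stand for less inhibition and higher numbers for more inhibition at the one concentration tested (going by the name of the read-out)), compound 1 `CC1=C(C(=O)OCc2ccccc2)C(c2cccs2)NC(=S)N1` gives 45%. Compound 2 `COC(=O)C1=C(C)N(C)C(=O)NC1c1ccco1` gives 31% in this assay, the lower of the two numbers and beyond the scatter below compound 1. Compound 3 `CC1=C(C(=O)OCC(C)C)C(c2ccco2)NC(=O)N1C` differs from compound 2 by isopropyl in place of hydrogen on a saturated chain carbon bound to an oxygen next to a carbonyl group. Within the data shown here, no measured pair shows this change, so nothing in the data sets its size. The step of a number 5 percentage points higher from compound 2 to compound 3 (within the scatter) is expected to stay within the scatter, perhaps with a slight rise. Compound 3 is therefore estimated at 36%, with a range from 15% to 60%.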

Compound 3, a percentage reported as inhibition, at one concentration (the size of the read-out at that concentration, not a potency): 4%
Estimate against measurement, compound 3: 32 percentage points above; measured number outside the range, below it.
By their numbers in this assay, from the lowest: compound 3; then compound 2; then compound 1.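

In this assay, the change from methoxycarbonyl to isobutoxycarbonyl gives a number 27 percentage points lower from compound 2 to compound 3 (beyond the scatter). Among these compounds, this is the first sign that the read-out responds to what sits at this place on the shared core, and that adding isopropyl here lowers inhibition rather than leaving it unchanged. Nothing available explains why the number falls.

The compounds shown leave open whether the loss grows gradually with chain size, as an ethyl or propyl ester would test. They also leave open how a carboxylic acid or an amide would read at this place.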